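The source may report more compounds than this note shows. Statements on the series, on what has been measured and on what is new or still open speak of the compounds shown alone.

Measured so far:
Compound 1 `CCn1c(/C=C2/C(=O)Nc3ccccc32)nc2ccccc21` — a limit only, > 50000 nM
Compound 2 `CC(C)n1c(/C=C2/C(=O)Nc3ccccc32)nc2ccccc21` — 38900 nM
Compound 3 `CCn1c(/C=C2/C(=O)Nc3ccc(Br)cc32)nc2ccccc21` — "not determined" (no result reported)

In a functional assay on BT-549 cells (Homo sapiens) for cytotoxicity, read by MTT assay, with a stated time of 48 h (a lower number here means a stronger inhibitor, a higher number a weaker inhibitor), compound 2 gives 38900 nM. For compound 1 the value is a limit of the assay and not a number, > 50000 nM. The step of an at least 1.2-fold higher number from compound 2 to compound 1 (0.10 log units; that floor lies within the scatter) is the change (hydrogen in place of methyl on a saturated chain carbon bound to an aromatic nitrogen and a saturated chain carbon); its floor is set because the limit of > 50000 nM in this assay, at which 1 of the 3 values shown sits, is where compound 1 sits. Compound 3 and compound 2 differ in more than one place, and the difference between their cores is not broken down here. Compound 4 `Cn1c(/C=C2/C(=O)Nc3ccc(Br)cc32)nc2ccccc21` has not yet been measured in this assay. It arises from compound 3 by hydrogen in place of methyl on a saturated chain carbon bound to an aromatic nitrogen, the same kind of change as that from compound 2 to compound 1, though the place differs: in compound 2 the carbon is bound to an aromatic nitrogen and a saturated chain carbon, in compound 3 only to an aromatic nitrogen. Since compound 3 has no number, the expectation for compound 4 rests only on compound 2 with 38900 nM and on compound 1 sitting at the limit of > 50000 nM in this assay, at which 1 of the 3 values shown sits. Compound 4 is therefore expected to give about 45000 nM, between 10000 nM and 150000 nM.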

Compound 4, half-maximal inhibitory concentration: > 50000 nM
Compound 4 was reported as a limit (the forecaster's own chance of this, stated with the estimate: 55%); middle value at least 1.1-fold (0.04 log units) from the limit.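

In this assay compound 4 gives > 50000 nM, which is a limit of the assay and not a number. For the compounds shown here, compound 3 has no reported result, so no step from compound 3 to compound 4 can be read. The compounds shown leave open whether the change from ethyl to methyl alters the read-out at all.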